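The source may report more compounds than this note shows. Statements on the series, on what has been measured and on what is new or still open speak of the compounds shown alone.

Going by the values given here, in a functional assay on MCF7 cells (Homo sapiens) for cytotoxicity, read by sulforhodamine B assay, with a stated time of 48 h (a higher number here means a weaker inhibitor, a lower number a stronger inhibitor), three compounds built on a shared core have numbers so far. Compound 1 `N#Cc1c(-c2ccc(Cl)cc2)cc(-c2ccc(Cl)cc2)n(CC(O)CCl)c1=O` gives 4.6 ug/mL, compound 2 `N#Cc1c(-c2ccc(Cl)cc2)cc(-c2ccc(Cl)cc2)n(CC2CO2)c1=O` gives 5 ug/mL and compound 3 `CC(=O)OC[C@H]1O[C@@H](n2c(-c3ccc(Cl)cc3)cc(-c3ccc(Cl)cc3)c(C#N)c2=O)[C@H](OC(C)=O)[C@@H](OC(C)=O)[C@@H]1OC(C)=O` gives 6.3 ug/mL. Compound 2 therefore stands level with the other two, since its gaps to both lie within the scatter. Compound 4 `CCn1c(-c2ccc(Cl)cc2)cc(-c2ccc(Cl)cc2)c(C#N)c1=O` has not yet been measured. It differs from compound 2 by one change: methyl in place of oxiran-2-yl on a saturated chain carbon bound to an aromatic nitrogen. In words, methyl takes the place of oxiran-2-yl on a saturated chain carbon bound to an aromatic nitrogen, so (oxiran-2-yl)methyl becomes ethyl. Among the compounds with values here, the one measured step at this place, a 1.1-fold higher number from compound 1 to compound 2 (0.04 log units; within the scatter), stays within the scatter, and compound 3, with a different substituent there, gives 6.3 ug/mL. Within the data shown here, no measured compound carries a plain ethyl, so the range has to stay generous. The step expected is a 1.2-fold higher number from compound 2 to compound 4 (0.08 log units; within the scatter), an estimated change no larger than the scatter. Compound 4 is expected at 6 ug/mL, with an estimated range of 3 ug/mL to 13 ug/mL.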

Compound 4, half-maximal inhibitory concentration: 19.7 ug/mL
The estimate for compound 4 lay 3.3-fold (0.52 log units) below the measured number, outside the stated range (above it).
By their numbers in this assay, from the lowest: compounds 1, 2 and 3 (each within the scatter of the next); then compound 4.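

In this assay, the group on the saturated chain carbon bound to an aromatic nitrogen now makes a measurable difference: the change gives a 3.9-fold higher number from compound 2 to compound 4 (0.60 log units; beyond the scatter), and the matching change from the open chain gives a 4.3-fold higher number from compound 1 to compound 4 (0.63 log units; beyond the scatter). The earlier step at this place, a 1.1-fold higher number from compound 1 to compound 2 (0.04 log units; within the scatter), could not show this, and the new steps show that a plain ethyl is what separates from the other two, while the oxiran-2-yl ring is not required, since 2-chloro-1-hydroxyethyl stands level with it. No measurement offered here explains the difference.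

The compounds shown leave open which part of the 2-chloro-1-hydroxyethyl group matters, as a chain bearing only a hydroxyl or only a chlorine would separate the two. They also leave open whether a plain propyl or a chain ending in an amine would behave like the ethyl of compound 4.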